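A few compounds are considered here, and "the series" means these few. Any claim that something is new, unique, unknown or untested is made for them only; others in the source may bear on it.

Among the measured compounds shown here, compound 2 `CCCCN(Cc1ccc(C#N)cc1)[C@@H]1CN[C@H](C(=O)N2CCSC2)C1` gives 5 nM in an assay on a cell-free system (plasma) for inhibition of Dipeptidyl peptidase 4 (Rattus norvegicus), read by fluorescence (a higher number here means a weaker inhibitor, a lower number a stronger inhibitor), the lowest of the two numbers so far; compound 1 `N#Cc1ccc(CN[C@@H]2CN[C@H](C(=O)N3CCSC3)C2)cc1` gives 34.3 nM. For the measured compounds named here, the one measured step, a 6.9-fold lower number from compound 1 to compound 2 (0.84 log units; beyond the scatter), shows that a substituent on the amine nitrogen in place of hydrogen lowers the number. Compound 3 `N#Cc1ccc(CN(Cc2ccc(C#N)cc2)[C@@H]2CN[C@H](C(=O)N3CCSC3)C2)cc1` carries 4-cyanophenyl in place of propyl on a saturated chain carbon bound to an amine nitrogen. Going by the values given here, no measured step compares one amine substituent with another, so the direction of this change is untested; the nitrogen stays substituted. The expected step is a 1.4-fold higher number from compound 2 to compound 3 (0.15 log units; within the scatter), within the scatter. The estimate for compound 3 is 7 nM, from 2 nM to 25 nM.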

Compound 3, half-maximal inhibitory concentration: 9.3 nM
Beside the measured number, compound 3's estimate is 1.3-fold (0.12 log units) below it; low and high end bracket the measured number.
By their numbers in this assay, from the lowest: compounds 2 and 3 (each within the scatter of the next); then compound 1.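

With 4-cyanobenzyl in place of hydrogen on the amine nitrogen, this assay shows a 3.7-fold lower number from compound 1 to compound 3 (0.57 log units; beyond the scatter) as well, so the lower number seen with butyl is not tied to that one substituent. Exchanging butyl for 4-cyanobenzyl, which brings in an aromatic ring and a nitrile, gives a 1.9-fold higher number from compound 2 to compound 3 (0.27 log units; within the scatter) and does not separate the two substituents. Still open, on these data alone, is whether a longer chain such as hexyl, or a substituent carrying a carboxylic acid or an amine, holds the number at this level on this nitrogen. Nothing shown gives a reason for either step.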